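The compounds below may be only part of what the source reports. "The series", "measured", "known", "first", "only" and "open" are said of these compounds alone.

Compound 1, `CCOC(=O)c1c(-c2ccc(OC)cc2)[nH]c2cccc(OC)c2c1=O`: in a physicochemical assay for solubility, in phosphate buffer, at pH 7.4 (on this read-out lower numbers stand for lower solubility and higher numbers for higher solubility), compound 1 gives > 100000 nM, which is a limit of the assay and not a number.
Compound 2, `CCOC(=O)c1c(-c2cccc(F)c2)[nH]c2cc(OC)ccc2c1=O`: in this assay compound 2 gives > 100000 nM, again a limit of the assay rather than a number.

Where compound 2 stands is therefore known only as a limit: the solubility reading for compound 2 is the upper limit reported, and no number sits behind it. The same holds for the only other value in hand, since the limit of > 100000 nM in this assay, at which 2 of the 2 values shown sit, describes both readings shown. Among the compounds with values here, no step between two measured compounds is available here, so no measured change in solubility can be drawn on.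

Compound 3, `CCOC(=O)c1c(-c2cccc(C)c2)[nH]c2cc(OC)ccc2c1=O`, has not yet been measured in this assay. Compared with compound 2 the change is methyl in place of fluoro on an aromatic carbon. Within the data shown here, since no measured step exists and both values shown sit at the limit, no shift beyond the usual scatter is expected from this change. Compound 3 is therefore expected to reach the limit of this assay as well, with an estimated solubility of 100000 nM, in a range from 30000 nM to 300000 nM. The step of a number no higher from compound 2 to compound 3 (the limit leaves the size open) that this estimate means is expected to be essentially none.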

Compound 3, solubility: 48000 nM
Compound 3: the middle estimate sits 2.1-fold (0.32 log units) above what was measured; the range from low to high includes it.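

In this assay, within the data shown here, the change from 3-fluorophenyl to 3-methylphenyl gives the first reading that is a number rather than a limit, and it brings a step beyond the scatter: an at least 2.0-fold lower number from compound 2 to compound 3 (0.31 log units; beyond the scatter). This place on the aromatic ring, meta to a large group, is therefore not silent in this read-out, even though one heavy atom simply replaces another and neither fluoro nor methyl brings a hydrogen-bond donor, a hydrogen-bond acceptor or a net charge. The step has only a lower bound, and its full size cannot be read: the limit of > 100000 nM in this assay, at which 2 of the 3 values shown sit.

From the compounds shown here alone, what an amine, a carboxylic acid or a longer chain at this same place would do in this assay remains open, so this single pair cannot show whether the step is particular to methyl or would follow from other replacements of fluoro. Going by these compounds, compound 1 differs from compound 3 in more than one place and offers no clean comparison, so it also remains open whether the same change would give a similar step on a differently substituted core.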